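A Fluoro Added to Compound 3

This account rests on a few compounds, and the source may have more. Where it says the series, first, only, none or still open, it means among the compounds named here.

In an ADME assay on A549 cells (Homo sapiens) for cytotoxicity, read by resazurin assay, with a stated time of 48 h (on this read-out higher numbers stand for lower toxicity in this test and lower numbers for higher toxicity in this test), compound 1 (`CCNc1ccc(NC(=O)c2cc(Cl)ccc2O)c(Cl)c1`) gives 30200 nM, compound 2 (`O=C(Nc1ccc(NCc2ccc(F)cc2)cc1Cl)c1cc(Cl)ccc1O`) gives 54400 nM, and compound 3 (`O=C(Nc1ccc(NCc2cccc(C(F)(F)F)c2)cc1Cl)c1cc(Cl)ccc1O`) gives 13300 nM, the lowest of the three numbers. Compound 4 (`O=C(Nc1ccc(NCc2cc(F)cc(C(F)(F)F)c2)cc1Cl)c1cc(Cl)ccc1O`) differs from compound 3 by fluoro in place of hydrogen on an aromatic carbon, meta to a trifluoromethyl group. Within the data shown here, no measured step isolates this change. The nearest evidence involves larger swaps at the same end of the molecule: a 1.8-fold higher number from compound 1 to compound 2 (0.26 log units; within the scatter), a 2.3-fold lower number from compound 1 to compound 3 (0.36 log units; beyond the scatter) and a 4.1-fold lower number from compound 2 to compound 3 (0.61 log units; beyond the scatter). Those steps are modest at most, so only a small change is expected. The expected step is a 1.2-fold lower number from compound 3 to compound 4 (0.08 log units; within the scatter), slightly downward and within the scatter. Compound 4 is estimated at 11000 nM, with an expected range of 5000 nM to 25000 nM.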

Compound 4, half-maximal cytotoxic concentration: 30900 nM
Beside the measured number, compound 4's estimate is 2.8-fold (0.45 log units) below it; measured number above the stated range.
By their numbers in this assay, from the lowest: compound 3; then compounds 1, 4 and 2 (each within the scatter of the next).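

On the read-out of this assay, fluoro in place of hydrogen, meta to a trifluoromethyl group, gives a 2.3-fold higher number from compound 3 to compound 4 (0.37 log units; beyond the scatter). The earlier steps shown here swapped whole groups at this end of the molecule, whereas this one shows that a single added fluorine atom on this aromatic ring can by itself move the number beyond the scatter, towards lower toxicity in this test. Nothing shown here gives a measured reason for this rise.

On these data alone, whether a chloro or a methoxy group on the same carbon would move the number the same way stays open. So does whether fluoro gives such a step on a ring without the trifluoromethyl group.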